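Swapping an Acyl Cap for a Phenylpropyl Chain

The source may hold more compounds than are shown below. What is called first, only, known or untested is meant among the compounds shown, and "the series" means these compounds.

Of the compounds shown here, three built on one shared core have been tested in an assay on CHO cells for displacement of a labelled ligand from adenosine receptor A1 (Homo sapiens), read by scintillation counting, with a stated time of 1 h, tested at 1 uM; a higher number here means more inhibition at the concentration tested (going by the name of the read-out), a lower number less inhibition. Compound 1, `Nc1ncc(-c2ccc(Cl)cc2)c(-c2ccccc2)n1`, gives 41% in this assay. Compound 2, `Nc1ncc(-c2ccncc2)c(-c2ccccc2)n1`, returns only a limit of this assay, recorded as > 80%. Compound 3, `CC(C)CC(=O)Nc1ncc(-c2cccc(Cl)c2)c(-c2ccccc2)n1`, gives 56% in this assay. Of the two plain numbers, compound 3 stands highest, and its gap to compound 1 is wider than the usual scatter of repeated measurements, so compound 3 sits clearly above compound 1 here. The reading for compound 2 is a limit and is set aside from that comparison; it is one of the values sitting at the limit of > 80% in this assay, at which 1 of the 3 values shown sits.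

The next compound, compound 4, `Clc1cccc(-c2cnc(NCCCc3ccccc3)nc2-c2ccccc2)c1`, is reached from compound 3 by a single change: 3-phenylpropyl in place of isobutylcarbonyl on a nitrogen on an aromatic ring. The shared core and the two aryl groups on it are kept; only the group on that nitrogen is exchanged.

For the measured compounds named here, no measured step between two compounds is available to gauge such a change. With the core unchanged, the expected step from compound 3 to compound 4 is a number 2 percentage points higher from compound 3 to compound 4 (within the scatter), that is, no shift beyond the scatter in either direction. Compound 4 is therefore estimated at 58%, within a range from 30% to 85%.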

Compound 4, a percentage reported as inhibition, at one concentration (the size of the read-out at that concentration, not a potency): 33%
For compound 4 the middle estimate is 25 percentage points above the measured one; low and high end bracket the measured number.
By their numbers in this assay, from the lowest: compounds 4 and 1 (each within the scatter of the next); then compound 3. At a limit, above all of these: compound 2.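

For the compounds shown here, exchanging the group on a nitrogen on an aromatic ring gives the first measured step in this assay: a number 23 percentage points lower from compound 3 to compound 4 (beyond the scatter). With the shared core and both aryl groups kept, this shows that the reading responds to what sits on that nitrogen, and that 3-phenylpropyl does not serve as a neutral replacement for isobutylcarbonyl. The swap alters several things at once, removing the carbonyl with its hydrogen-bond acceptor and adding a six-membered aromatic ring on a larger group, and nothing available here bears on which of these differences lies behind the step.

The compounds shown leave open how a plain propyl chain on the same nitrogen would read, since it would lack both the carbonyl and the phenyl ring, and how a 3-phenylpropanoyl group would read, since it would hold the carbonyl and the phenyl ring together. Also open, going by these compounds, is whether an amine or a carboxylic acid at the end of the chain would move the reading in either direction, as one step at one position cannot yet show a trend.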